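Swapping phenyl for phenylsulfanyl on a biphenyl acid

The source may hold more compounds than are shown below. What is called first, only, known or untested is meant among the compounds shown, and "the series" means these compounds.

Of the compounds shown here, three have been measured so far in an assay (strain CD) for inhibition of 3-hydroxy-3-methylglutaryl-coenzyme A reductase (Rattus norvegicus), read by scintillation counting, using microsomes, with a stated time of 90 min; on this read-out higher numbers stand for weaker inhibition and lower numbers for stronger inhibition. Compound 1 `CC(CCc1ccc(-c2ccccc2)cc1)CC(=O)O` gives 2000 nM, the lowest number of the three. Compound 2 `CC(CC(=O)O)CC(=O)c1ccc(Oc2ccccc2)cc1` gives 290000 nM, and compound 3 `CC(CC(=O)O)CC(=O)c1ccc(Sc2ccccc2)cc1` gives 240000 nM. Compound 1 stands far apart from both, with compound 3 nearest and compound 2 furthest, each gap lying beyond the scatter.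

The new compound 4 `CC(CCc1ccc(Sc2ccccc2)cc1)CC(=O)O` differs from compound 1 in one place: phenylsulfanyl in place of phenyl on an aromatic carbon. Among the compounds with values here, no measured pair shows exactly this change. The closest guide is the pair of compound 2 and compound 3, where phenylsulfanyl replaced phenoxy and a 1.2-fold lower number from compound 2 to compound 3 (0.08 log units; within the scatter) was found, a move too small to count. That pair exchanged one linked ring for another; the present change adds a sulfur link where there was none, so the guide is only partial.

With that in mind, compound 4 is expected to show no change at the digits printed from compound 1 to compound 4 (within the scatter) in this assay, with no move beyond the scatter. The estimated value for compound 4 is 2000 nM, within a range from 500 nM to 8000 nM.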

Compound 4, half-maximal inhibitory concentration: 20000 nM
For compound 4 the middle estimate is 10-fold (1.00 log units) below the measured one; the measured number lies above the stated range.
By their numbers in this assay, from the lowest: compound 1; then compound 4; then compounds 3 and 2 (each within the scatter of the next).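

In this assay, this aromatic carbon proves sensitive to the group it carries: phenylsulfanyl in place of phenyl gives a 10-fold higher number from compound 1 to compound 4 (1.00 log units; beyond the scatter), a step beyond the scatter and toward weaker inhibition. Within the data shown here, until now, phenylsulfanyl had been compared only with phenoxy, in a 1.2-fold lower number from compound 2 to compound 3 (0.08 log units; within the scatter), and that step stayed within the scatter, so this is the first sign that swapping in phenylsulfanyl can matter. Nothing measured here gives a reason for the size of this step.

The compounds shown leave open how a benzyl group or an amine would fare at this place on the core of compound 1, and whether phenoxy there would match phenylsulfanyl. As far as these compounds go, it also remains open whether phenyl would give the same advantage over phenylsulfanyl on the core of compound 3.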